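Second carboxylic acid in place of the aromatic chloro

A few compounds are considered here, and "the series" means these few. Any claim that something is new, unique, unknown or untested is made for them only; others in the source may bear on it.

Compounds measured so far:
compound 1, `O=C(O)CCc1ccc(NCc2ccc(Cl)cc2)cc1`: 111%
compound 2, `O=C(O)CCc1ccc(NCc2ccc3ccccc3c2)cc1`: 123%
compound 3, `O=C(O)CCc1ccc(NCc2ccccc2Cl)cc1`: 122%

In a functional assay on CHO cells for agonist activity at Free fatty acid receptor 1 (Homo sapiens), read by reporter gene assay (a lower number here means a smaller maximal response, a higher number a larger maximal response), compound 1 gives 111%, the lowest of the three numbers. Compound 3 sits above it by a margin beyond the scatter, and compound 2 lies furthest from it, also beyond the scatter. All three compounds share the same core and differ only in the substituent carried on the benzyl ring attached to the aniline nitrogen.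

Compound 4, `O=C(O)CCc1ccc(NCc2ccc(C(=O)O)cc2)cc1`, has not yet been measured in this assay. Its structural difference from compound 1 is carboxy in place of chloro on an aromatic carbon; the place of the change is an aromatic carbon of a six-membered aromatic ring of carbon only, para to a large group. Within the data shown here, no single-change step between measured compounds is available for this exchange. For the step from compound 1 to compound 4 in this assay a modest downward shift is expected, a number 13 percentage points lower from compound 1 to compound 4 (beyond the scatter), close to the edge of the scatter. Compound 4 is therefore estimated to reach 98%, in a range from 70% to 125%.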

Compound 4, largest response reached (reported as percent of maximum), in percent of the reference or control that the assay uses: 9%
Compound 4: the middle estimate sits 89 percentage points above what was measured, and the stated range ends above it.
By their numbers in this assay, from the lowest: compound 4; then compound 1; then compounds 3 and 2 (each within the scatter of the next).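

In this assay, carboxy in place of chloro on this aromatic carbon, para to a large group, gives a number 102 percentage points lower from compound 1 to compound 4 (beyond the scatter). Among these compounds, this is the first single-place change, and it shows that the maximal response depends strongly on the group at this carbon, which compounds 1, 2 and 3, all with high responses, could not reveal. Nothing available here accounts for the loss of response.

On these data alone, it remains open whether the drop is specific to the carboxylic acid, or whether a methyl ester, a primary amide, a tetrazole or an amine at this carbon would give a similar response. As far as these compounds go, it is also open whether a carboxy group on the carbon that carries the chloro in compound 3 would have the same result.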